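From cyclopentylamino to pentyloxy on a shared core

A few compounds are considered here, and "the series" means these few. Any claim that something is new, unique, unknown or untested is made for them only; others in the source may bear on it.

In an ADME assay on CCRF-HSB-2 cells (Homo sapiens) for cytotoxicity, with a stated time of 7 days (on this read-out lower numbers stand for higher toxicity in this test and higher numbers for lower toxicity in this test), compound 1 (`CCOc1nc(N)nc2c1ncn2/C=C1/CC1(CO)CO`) gives > 20000 nM as a limit and not a number. Compound 2 (`CN(C)c1nc(N)nc2c1ncn2/C=C1/CC1(CO)CO`) gives > 20000 nM as a limit as well. Compound 3 (`Nc1nc(NC2CCCC2)c2ncn(/C=C3/CC3(CO)CO)c2n1`) gives > 20000 nM as a limit too. The whole record so far is the limit of > 20000 nM in this assay, at which 3 of the 3 values shown sit, and no exact value exists for any compound.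

The next compound is compound 4 (`CCCCCOc1nc(N)nc2c1ncn2/C=C1/CC1(CO)CO`). The change from compound 3 is pentyloxy in place of cyclopentylamino on an aromatic carbon and amounts to pentyloxy in place of cyclopentylamino on an aromatic carbon.

Among the measured compounds shown here, the steps that bear on this are a step that the two limits leave unreadable from compound 1 to compound 2 and a step that the two limits leave unreadable from compound 1 to compound 3 and a step that the two limits leave unreadable from compound 2 to compound 3 and each of them changes the group on an aromatic carbon. Their sizes cannot be read, so they offer only weak guidance. Ethoxy, dimethylamino and cyclopentylamino all end at the same limit, so the working expectation is that pentyloxy will too. The estimated change is a number no higher from compound 3 to compound 4 (the limit leaves the size open) and no clear step in either direction is expected in this assay from this evidence. For compound 4 the estimated value is 20000 nM with an expected range from 8000 nM to 40000 nM in this test.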

Compound 4, half-maximal cytotoxic concentration: > 20000 nM
Compound 4: a limit, no number; the forecaster's own chance of this, stated with the estimate: 70%; the middle value sits exactly at the limit.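

Among the compounds shown here, compound 4 also gives a limit and not a number in this assay, so no step from compound 1, compound 2 or compound 3 to compound 4 can be read. All four compounds share one limit: the limit of > 20000 nM in this assay, at which 4 of the 4 values shown sit. Going by these compounds, whether any of these groups on the shared core alters cytotoxicity, and by how much, stays open.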